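Difluoromethoxy for Chloro on the Pendant Phenyl

The source may report more compounds than this note shows. Statements on the series, on what has been measured and on what is new or still open speak of the compounds shown alone.

Compound 2 `Cn1nc2c(=O)n(CC3(O)CCN(Cc4ccc(-c5ccco5)cc4Cl)CC3)cnc2c1-c1ccc(Cl)cc1` gives 143 nM in an assay on isolated protein for inhibition of ubiquitin carboxyl-terminal hydrolase 7 (Homo sapiens), with stated times of 30 min and 2 h (a higher number here means a weaker inhibitor, a lower number a stronger inhibitor), the lowest of the three numbers measured, though compound 1 sits within the scatter of it. Compound 1 `Cn1nc2c(=O)n(CC3(O)CCN(Cc4ccc(-c5n[nH]c(=O)o5)cc4Cl)CC3)cnc2c1-c1ccc(CN)cc1` gives 171 nM. Compound 3 `Cn1nc2c(=O)n(CC3(O)CCN(Cc4ccc(-c5ncco5)cc4Cl)CC3)cnc2c1-c1ccc(CN)cc1` gives 1120 nM, the furthest from compound 2 and beyond the scatter. Compounds 1 and 2 differ in two places, so their values show only that both lie close together. Among the measured compounds shown here, the one single-point step measured is a 6.5-fold higher number from compound 1 to compound 3 (0.82 log units; beyond the scatter), and it concerns the five-membered ring on the benzyl part of the shared core, not the phenyl attached to the core itself. Compound 4 `Cn1nc2c(=O)n(CC3(O)CCN(Cc4ccc(-c5ccco5)cc4Cl)CC3)cnc2c1-c1ccc(OC(F)F)cc1` carries difluoromethoxy in place of chloro on an aromatic carbon. For the measured compounds named here, no measured step bears on this change: the chloro of compound 2 is varied nowhere among the measured compounds, and the difluoromethoxy appears in none of them. With nothing to lean on, the step expected is a 1.4-fold higher number from compound 2 to compound 4 (0.15 log units; within the scatter), no change beyond the scatter in either direction. Compound 4 is therefore estimated at 200 nM, with a range of 70 nM to 600 nM.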

Compound 4, half-maximal inhibitory concentration: 179 nM
Estimate against measurement, compound 4: 1.1-fold (0.05 log units) above, within the range that was stated.
By their numbers in this assay, from the lowest: compounds 2, 1 and 4 (each within the scatter of the next); then compound 3.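

In this assay the exchange of chloro for difluoromethoxy, on an aromatic carbon para to a large group, gives a 1.3-fold higher number from compound 2 to compound 4 (0.10 log units; within the scatter) and so leaves the two compounds indistinguishable. Among the compounds shown here, this is the first reading at the pendant phenyl, and it shows that difluoromethoxy can stand here in place of chloro without a shift beyond the scatter, whereas the one earlier step concerned the five-membered ring on the benzyl part. No measurement on these compounds offers an explanation for this result.

Compound 1 and compound 3 carry an aminomethyl group at this place but also differ from compound 2 elsewhere, so the contribution of that group alone stays unread. Going by these compounds, whether a bare hydrogen, a nitrile, a carboxylic acid or a longer alkoxy chain would fit here as well remains open.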